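Replacing the Aryl Group on a Ring Amine Nitrogen

A few compounds are considered here, and "the series" means these few. Any claim that something is new, unique, unknown or untested is made for them only; others in the source may bear on it.

Three compounds built on a shared core have been examined in a functional assay on HL-60 cells (Homo sapiens) for inhibition, read by MTT assay, with a stated time of 72 h; on this read-out higher numbers stand for weaker inhibition and lower numbers for stronger inhibition. Compound 1 `CCc1nc(-c2ccc(OC)cc2)c(C(=O)N2CCN(c3cccc(Cl)c3)CC2)o1` returned only a limit in this assay, > 1000 nM, rather than a number. Compound 2 `COc1cc(OC)cc(N2CCN(C(=O)c3oc(C)nc3-c3cccc(F)c3)CC2)c1` gives 28.2 nM in this assay. Compound 3 `Cc1nc(-c2ccccc2)c(C(=O)N2CCN(c3c(C)cccc3C)CC2)o1` gives 146 nM in this assay, which is the higher of the two numbers available; compound 2 sits clearly lower, a separation that lies beyond the usual scatter of repeated runs. Among the three values, the one for compound 1 rests at the assay's edge (the limit of > 1000 nM in this assay, at which 1 of the 3 values shown sits).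

Compound 4 `Cc1ccc(N2CCN(C(=O)c3oc(C)nc3-c3ccccc3)CC2)cc1` is the next compound awaiting measurement in this assay. It differs from compound 3 in one place: 4-methylphenyl in place of 2,6-dimethylphenyl on an amine nitrogen in a ring. Among the measured compounds shown here, no measured pair in this set isolates exactly this exchange, so any forecast rests on compound 3 itself and on the spread seen across compounds 1 and 2. The expected step of a 1.3-fold lower number from compound 3 to compound 4 (0.12 log units; within the scatter) in this assay is judged to be small, most likely within the scatter and in no firm direction. Compound 4 is accordingly estimated at 110 nM in this assay, with a plausible range from 30 nM to 450 nM.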

Compound 4, half-maximal inhibitory concentration: > 1000 nM
Compound 4: a limit, no number; the forecaster's own chance of this, stated with the estimate: 10%; middle value at least 9.0-fold (0.95 log units) from the limit.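

In this assay, compound 4 gives > 1000 nM, which is a limit and not a number. Among the compounds shown here, the exchange of 2,6-dimethylphenyl for 4-methylphenyl on the amine nitrogen in the ring is the first one-place change available in this set, and it brings an at least 6.8-fold higher number from compound 3 to compound 4 (0.83 log units; beyond the scatter), so this position does not tolerate every aryl group alike, even when the two groups differ by a single carbon. The step is bounded on one side only, so its full size stays unknown, and the limit now recurs among the compounds shown: the limit of > 1000 nM in this assay, at which 2 of the 4 values shown sit.

The compounds shown leave open whether 2-methylphenyl or 2-methoxyphenyl at this nitrogen would read like compound 3 or like compound 4. On these data alone, compound 1 and compound 2 differ from compound 3 in more than one place, so they cannot show what the aryl group does alone, and how a non-aromatic group such as cyclohexyl on the same nitrogen would read also remains open.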